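Branched alkoxy in place of a straight chain

The source may hold more compounds than are shown below. What is called first, only, known or untested is meant among the compounds shown, and "the series" means these compounds.

In an assay on cells for antagonist activity at transient receptor potential cation channel subfamily V member 1 (Homo sapiens), read by FLIPR and calcium flux, with a stated time of 6 min (on this read-out higher numbers stand for weaker inhibition and lower numbers for stronger inhibition), compound 1 `CCC1CCN(c2nc(C(C)(C)C)ccc2CNC(=O)C(C)c2ccc(NS(C)(=O)=O)c(F)c2)CC1` gives 0.1 nM, and compound 2 `CCCOc1nc(C(C)(C)C)ccc1CNC(=O)C(C)c1ccc(NS(C)(=O)=O)c(F)c1` gives 1.7 nM, the higher of the two numbers. Going by the values given here, the one measured step, a 17-fold higher number from compound 1 to compound 2 (1.23 log units; beyond the scatter), concerns a different position and does not bear on the change at hand. Compound 3 `CC(C)Oc1nc(C(C)(C)C)ccc1CNC(=O)C(C)c1ccc(NS(C)(=O)=O)c(F)c1` differs from compound 2 by isopropyl in place of propyl on an oxygen on an aromatic ring. Among the compounds with values here, with no measured step on this oxygen, a step within the scatter is expected. Compound 3 is therefore estimated at 2 nM, in a range from 0.7 nM to 6 nM. The expected step is a 1.2-fold higher number from compound 2 to compound 3 (0.07 log units; within the scatter), within the scatter.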

Compound 3, inhibition constant: 2.3 nM
The estimate for compound 3 lay 1.2-fold (0.06 log units) below the measured number; the range from low to high includes it.
By their numbers in this assay, from the lowest: compound 1; then compounds 2 and 3 (each within the scatter of the next).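

In this assay, branching the chain on this oxygen gives a 1.4-fold higher number from compound 2 to compound 3 (0.13 log units; within the scatter), so the shape of this chain, propyl or isopropyl, makes no distinguishable difference here. Replacing 4-ethylpiperidin-1-yl with isopropoxy gives a 23-fold higher number from compound 1 to compound 3 (1.36 log units; beyond the scatter), so branching does not close the large gap already seen with propoxy. No evidence is available to explain either step. Going by these compounds, whether a methoxy group, a longer chain or a cyclopentyloxy group on this oxygen would behave the same stays open. So does whether an amine other than 4-ethylpiperidin-1-yl would keep the low number of compound 1.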